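Reversed enone and chloro swap on a pyrazolopyrimidine chalcone

This account rests on a few compounds, and the source may have more. Where it says the series, first, only, none or still open, it means among the compounds named here.

Measured compounds:
compound 1 `COc1ccc(C(=O)/C=C/c2cc(-c3cc(OC)c(OC)c(OC)c3)n3nc(-c4ccccc4)cc3n2)cc1` 13200 nM
compound 2 `COc1cc(C(=O)/C=C/c2cc(-c3cc(OC)c(OC)c(OC)c3)n3nc(-c4ccccc4)cc3n2)cc(OC)c1OC` 24300 nM
compound 3 `COc1ccc(-c2cc(/C=C/C(=O)c3cc(OC)c(OC)c(OC)c3)nc3cc(-c4ccccc4)nn23)cc1OC` 4700 nM

In a functional assay on MDA-MB-231 cells (Homo sapiens) for antiproliferative activity, read by MTT assay, with a stated time of 24 h (on this read-out higher numbers stand for weaker inhibition and lower numbers for stronger inhibition), compound 1 gives 13200 nM, the second highest of the three numbers; its nearest neighbour is compound 2 at 24300 nM, and the furthest is compound 3 at 4700 nM. The step of a 1.8-fold higher number from compound 1 to compound 2 (0.27 log units; within the scatter) lies within the scatter, while a 5.2-fold lower number from compound 2 to compound 3 (0.71 log units; beyond the scatter) is a modest but real drop. Compound 4 `COc1cc(-c2cc(C(=O)/C=C/c3ccc(Cl)cc3)nc3cc(-c4ccccc4)nn23)cc(OC)c1OC` has not yet been measured. Relative to compound 1 the change is (2-(4-chlorophenyl)ethenyl)carbonyl in place of 2-((4-methoxyphenyl)carbonyl)ethenyl on an aromatic carbon. For the measured compounds named here, no measured step repeats this exact change: the first step swaps only the aryl group on the carbonyl carbon, and the second step, which yields the lowest number through compound 3, combines a loss of a methoxy with the rearranged enone that compound 4 also carries. Going by the values given here, the weight of compound 3 at 4700 nM argues for a somewhat lower number than compound 1, but the 4-chlorophenyl group has no precedent here, so the expected step of a 1.7-fold lower number from compound 1 to compound 4 (0.22 log units; within the scatter) is small and uncertain. Compound 4 is therefore estimated at 8000 nM, with a range from 2500 nM to 25000 nM in this assay.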

Compound 4, half-maximal inhibitory concentration: 21600 nM
Compound 4: the middle estimate sits 2.7-fold (0.43 log units) below what was measured; measured number inside the range.
By their numbers in this assay, from the lowest: compound 3; then compounds 1, 4 and 2 (each within the scatter of the next).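

At the aromatic carbon next to the ring nitrogen, (2-(4-chlorophenyl)ethenyl)carbonyl replaces 2-((4-methoxyphenyl)carbonyl)ethenyl, and in this assay this gives a 1.6-fold higher number from compound 1 to compound 4 (0.21 log units; within the scatter). The earlier steps shown here altered only the aryl group on the carbonyl carbon or a methoxy on an aromatic carbon, whereas this one reverses the enone and exchanges the 4-methoxyphenyl group for 4-chlorophenyl at once, and the combined change stays within the usual scatter of the read-out. Nothing shown explains this outcome, and the single step cannot say whether the two alterations have little effect each or offset one another.

The compounds shown leave open what the reversed enone does on its own, since no pair here isolates it from the exchange of the aryl group, and the same is true of the chlorine. They also leave open how the number would respond if an amine or a carboxylic acid stood in place of that chlorine on the phenyl ring of the reversed enone.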